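The compounds below may be only part of what the source reports. "The series", "measured", "known", "first", "only" and "open" are said of these compounds alone.

Compounds measured in a functional assay on PC-3 cells (Homo sapiens) for cytotoxicity, read by MTT assay, with a stated time of 72 h; a lower number here means a stronger inhibitor of growth, a higher number a weaker inhibitor of growth:
compound 1 `CCCOC(=O)Nc1ccc([Se]C#N)cc1`: 47400 nM
compound 2 `CCCCCCOC(=O)Nc1ccc([Se]C#N)cc1`: 44600 nM
compound 3 `N#C[Se]c1ccc(NC(=O)Oc2ccc(Cl)cc2)cc1`: 18700 nM

Compound 3 gives the lowest of the three numbers in this assay, and its gaps to compound 2 and to compound 1 both lie beyond the scatter. Compound 4 `N#C[Se]c1ccc(NC(=O)Oc2ccccc2)cc1` differs from compound 3 by hydrogen in place of chloro on an aromatic carbon. Within the data shown here, the only measured step, a 1.1-fold lower number from compound 1 to compound 2 (0.03 log units; within the scatter), alters the chain on the carbamate side and leaves the aromatic part untouched, so no measured pair speaks to a change of this kind. With nothing to suggest a shift beyond the scatter, the step of a 1.3-fold higher number from compound 3 to compound 4 (0.13 log units; within the scatter) is expected to be small. Compound 4 is therefore estimated at 25000 nM, with a range of 10000 nM to 60000 nM.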

Compound 4, concentration for total growth inhibition: 37500 nM
Beside the measured number, compound 4's estimate is 1.5-fold (0.18 log units) below it; the measured number falls inside the stated range.
By their numbers in this assay, from the lowest: compounds 3, 4, 2 and 1 (each within the scatter of the next, the first and the last beyond it).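

Among these compounds, with hydrogen in place of chloro on the aromatic carbon para to a large group, a 2.0-fold higher number from compound 3 to compound 4 (0.30 log units; within the scatter) gives the first direct reading of this position in this assay, and the change does not go beyond the scatter. Phenyl in place of hexyl gives a 1.2-fold lower number from compound 2 to compound 4 (0.08 log units; within the scatter), and phenyl in place of propyl gives a 1.3-fold lower number from compound 1 to compound 4 (0.10 log units; within the scatter), so an aromatic group on this oxygen reads level with both chains. No evidence at hand bears on these results.

On these data alone, whether fluoro, methoxy or an amine on that aromatic carbon would give a step beyond the scatter stays open. So does the reading for an octyl chain on the oxygen.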